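One number, two limits, and compound 4

This account rests on a few compounds, and the source may have more. Where it says the series, first, only, none or still open, it means among the compounds named here.

Among the measured compounds shown here, in a functional assay on MCF7 cells (Homo sapiens) for inhibition, read by MTT assay, with a stated time of 72 h (on this read-out lower numbers stand for stronger inhibition and higher numbers for weaker inhibition), compound 1 `CN1CCN(c2cc(C(F)(F)F)nc(SCc3ccc(C(F)(F)F)cc3)n2)CC1` gives 30200 nM, the only true number among the three compounds measured. Compound 2 `FC(F)(F)c1ccc(CSc2nc(N3CCN(c4ccccc4)CC3)cc(C(F)(F)F)n2)cc1` gives > 50000 nM, which is a limit of the assay and not a number. Compound 3 `FC(F)(F)c1ccc(CSc2nc(N3CCN(c4ncccn4)CC3)cc(C(F)(F)F)n2)cc1` gives > 50000 nM, which is also a limit.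

Compound 4 `FC(F)(F)c1ccc(CSc2nc(Sc3ccccn3)cc(C(F)(F)F)n2)cc1` has not been measured, and it differs from compound 1 as follows: (pyridin-2-yl)sulfanyl in place of 4-methylpiperazin-1-yl on an aromatic carbon. The closest evidence comes from two changes on the amine nitrogen of the ring that compound 4 gives up: an at least 1.6-fold higher number from compound 1 to compound 2 (0.21 log units; that floor lies within the scatter) and an at least 1.6-fold higher number from compound 1 to compound 3 (0.21 log units; that floor lies within the scatter). Both are only minimum sizes, set by the limit of > 50000 nM in this assay, at which 2 of the 3 values shown sit, and both point towards higher numbers, which here mean weaker inhibition. Neither change removes the ring itself, so together they offer only a loose guide. The expected result is a 1.5-fold higher number from compound 1 to compound 4 (0.17 log units; within the scatter), so no step beyond the scatter is expected. For compound 4 the estimated value is 45000 nM, with an expected range from 15000 nM to 120000 nM.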

Compound 4, half-maximal inhibitory concentration: 43200 nM
For compound 4 the middle estimate is 1.0-fold (0.02 log units) above the measured one; low and high end bracket the measured number.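

Compounds 2 and 3 changed only the group on the amine nitrogen and kept the ring of compound 1, whereas compound 4 replaces the whole 4-methylpiperazin-1-yl group on this aromatic carbon with (pyridin-2-yl)sulfanyl. In this assay, this exchange of a non-aromatic ring with two nitrogens for a sulfur-linked aromatic ring gives a 1.4-fold higher number from compound 1 to compound 4 (0.16 log units; within the scatter), so even a change this large at this position produces no step beyond the scatter. How compound 4 compares with compound 2 and compound 3 cannot be read, because those two values are limits: the limit of > 50000 nM in this assay, at which 2 of the 4 values shown sit.

From the compounds shown here alone, it remains open whether the sulfur atom or the aromatic ring of (pyridin-2-yl)sulfanyl matters more for this result. Also open, going by these compounds, is how a morpholine ring, a carboxylic acid or a longer alkyl chain on this carbon would read.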